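A few compounds are considered here, and "the series" means these few. Any claim that something is new, unique, unknown or untested is made for them only; others in the source may bear on it.

The series shares one core in which a substituent sits on a nitrogen on an aromatic ring. Compound 1 `CCCCNc1nc(C(F)(F)F)ccc1CNC(=O)C(C)c1ccc(NS(C)(=O)=O)c(F)c1` carries butyl there and, in a functional assay on CHO-K1 cells for antagonist activity at transient receptor potential cation channel subfamily V member 1 (Homo sapiens), read by FLIPR (a higher number here means a weaker inhibitor, a lower number a stronger inhibitor), compound 1 gives 9.1 nM. Compound 2 `CC(C(=O)NCc1ccc(C(F)(F)F)nc1Nc1ccc(F)cc1)c1ccc(NS(C)(=O)=O)c(F)c1` carries 4-fluorophenyl, and in this assay compound 2 gives 39.2 nM. Compound 3 `Cc1ccc(Nc2nc(C(F)(F)F)ccc2CNC(=O)C(C)c2ccc(NS(C)(=O)=O)c(F)c2)cc1C` carries 3,4-dimethylphenyl, and compound 3 gives 39.3 nM. Compound 3 thus sits alongside compound 2, the pair separated only by a 1.0-fold higher number from compound 2 to compound 3 (0.00 log units; within the scatter), while both stand apart from compound 1 by a 4.3-fold higher number from compound 1 to compound 2 (0.63 log units; beyond the scatter) and a 4.3-fold higher number from compound 1 to compound 3 (0.64 log units; beyond the scatter).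

Compound 4 `CC(C(=O)NCc1ccc(C(F)(F)F)nc1NCc1ccc(Cl)cc1)c1ccc(NS(C)(=O)=O)c(F)c1` is obtained from compound 3 by 4-chlorobenzyl in place of 3,4-dimethylphenyl on a nitrogen on an aromatic ring. For the measured compounds named here, the steps that bear on this change are the two from the butyl chain to an aryl group, both modest and in the same direction, and the step between the two aryl groups, which showed nothing beyond the scatter. A benzyl group carries a ring like the aryl groups yet attaches through a chain link as butyl does, and the measured steps cannot settle which behaviour it follows. Compound 4 is therefore expected to give a number somewhat lower than that of compound 3. For compound 4 the expected step is a 2.0-fold lower number from compound 3 to compound 4 (0.29 log units; within the scatter). The estimate for compound 4 is 20 nM, with a range from 6 nM to 65 nM.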

Compound 4, inhibition constant: 65.7 nM
Estimate against measurement, compound 4: 3.3-fold (0.52 log units) below, outside the stated range (above it).
By their numbers in this assay, from the lowest: compound 1; then compounds 2, 3 and 4 (each within the scatter of the next).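

In this assay the 4-chlorobenzyl group falls with the two aryl groups and not with butyl: the data give a 1.7-fold higher number from compound 3 to compound 4 (0.22 log units; within the scatter) and a 1.7-fold higher number from compound 2 to compound 4 (0.22 log units; within the scatter) for the aryl comparisons, against a 7.2-fold higher number from compound 1 to compound 4 (0.86 log units; beyond the scatter) for butyl. At this position, then, a chain link between the nitrogen and the ring does not bring the number back to that of compound 1, and among these four compounds butyl alone stands apart. No measurement shown here explains this difference.

The compounds shown leave open whether the ring itself separates compounds 2, 3 and 4 from compound 1, which a cyclohexylmethyl group could test. They also leave open how a longer chain, such as hexyl, or an unsubstituted benzyl group would compare with butyl and 4-chlorobenzyl.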